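A few compounds are considered here, and "the series" means these few. Any claim that something is new, unique, unknown or untested is made for them only; others in the source may bear on it.

Series notes.

Measured so far:
- compound 1, `C=CCn1c(SCC(=O)Nc2ccc(C(C)=O)cc2)nnc1-c1ccccc1`: 52%
- compound 2, `COc1cc(-c2nnc(SCC(=O)Nc3ccc(/C(C)=N/O)cc3)n2-c2ccccc2)cc(OC)c1OC`: 62%

Both were read in a functional assay on the whole organism (strain albino) for inhibition, with Rattus norvegicus as the target, read by paw edema, with stated times of 30 min and 2 h, at a dose of 0.28 mmol/kg by the oral route; a higher number here means more inhibition at the dose given (going by the name of the read-out), a lower number less inhibition. In this assay compound 1 gives 52%, and compound 2 gives 62%. Compound 1 holds the lower of the two numbers, but its gap to compound 2 lies within the usual scatter, so no order between the two is claimed. Going by the values given here, compound 2 differs from compound 1 in more than one place, and no single-place step between them is available.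

Not yet measured is compound 3, `C=CCn1c(SCC(=O)Nc2ccc(/C(C)=N/O)cc2)nnc1-c1ccccc1`. Its change from compound 1: a group of 4 heavy atoms (2 carbon, 1 nitrogen, 1 oxygen; no ring) in place of a group of 3 heavy atoms (2 carbon, 1 oxygen; no ring), on an aromatic carbon. Compound 2 also carries the entering group and gives 62%, a number close to that of compound 1. Among the compounds with values here, with no single-place step to go by, the expectation for compound 3 is a step from compound 1 that stays within the scatter, upward if anything. Compound 3 is estimated at 57%, range 45% to 69%. The expected step of a number 5 percentage points higher from compound 1 to compound 3 (within the scatter) is small.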

Compound 3, a percentage reported as inhibition, in the whole organism at one dose (the size of the read-out at that dose, not a potency): 63%
Compound 3: middle estimate off by 6 percentage points, on the low side, and the stated range covers the measured number.
By their numbers in this assay, from the lowest: compounds 1, 2 and 3 (each within the scatter of the next, the first and the last beyond it).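

In this assay, the change on this aromatic carbon can now be read alone: the acetyl gives way to the group of 4 heavy atoms (2 carbon, 1 nitrogen, 1 oxygen), with the rest of compound 1 kept, and the result is a number 11 percentage points higher from compound 1 to compound 3 (beyond the scatter) at the dose given. The position is therefore sensitive to this exchange, modestly so, which the pair of compound 1 and compound 2 could not show, since those two differ in more than one place. Nothing at hand accounts for the step.

Open, from the compounds shown here alone, is how an amine or a carboxylic acid on the same aromatic carbon would read against the acetyl. Open too, going by these compounds, is whether the step carries over to the core of compound 2.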